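The source may report more compounds than this note shows. Statements on the series, on what has been measured and on what is new or still open speak of the compounds shown alone.

Measured compounds:
compound 1, `N#Cc1c(N2CCC(c3ccccc3)CC2)ccn(CC2CC2)c1=O`, 309% in a functional assay on CHO cells for positive allosteric modulation of metabotropic glutamate receptor 2 (Homo sapiens), with a stated time of 30 min; a lower number here means a smaller maximal response, a higher number a larger maximal response;
compound 2, `N#Cc1c(N2CCC(c3ccc(F)cc3)CC2)ccn(CC2CC2)c1=O`, 258%;
compound 3, `COc1ccc(C2CCN(c3ccn(CC4CC4)c(=O)c3C#N)CC2)cc1`, 257%.

Compound 3 has the lowest of the three numbers in this assay, though compound 2 sits within the scatter of it; only compound 1 stands clearly higher. Compound 4, `N#Cc1c(N2CCC(c3c(F)cccc3F)CC2)ccn(CC2CC2)c1=O`, differs from compound 3 by 2,6-difluorophenyl in place of 4-methoxyphenyl on a saturated ring carbon. For the measured compounds named here, two measured steps bear on this: a number 51 percentage points lower from compound 1 to compound 2 (beyond the scatter) and a number 52 percentage points lower from compound 1 to compound 3 (beyond the scatter), both large drops on putting a substituent onto the aromatic ring. Between the two substituted rings, a number 1 percentage points lower from compound 2 to compound 3 (within the scatter), nothing beyond the scatter. Going by the values given here, no measured step covers two fluorines, so compound 4 is expected to stay near the substituted pair, with a number 7 percentage points lower from compound 3 to compound 4 (within the scatter), and its value in this assay is estimated at 250%, between 195% and 305%.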

Compound 4, largest response reached (Emax), in percent of the reference or control that the assay uses: 291%
Compound 4: middle estimate off by 41 percentage points, on the low side; low and high end bracket the measured number.
By their numbers in this assay, from the lowest: compounds 3 and 2 (each within the scatter of the next); then compound 4; then compound 1.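

In this assay, a substituent on the aromatic ring does not set one common level of response: 2,6-difluorophenyl gives a number 34 percentage points higher from compound 3 to compound 4 (beyond the scatter) and a number 33 percentage points higher from compound 2 to compound 4 (beyond the scatter), so the pair with 4-methoxyphenyl and 4-fluorophenyl does not speak for every substituted ring. The unsubstituted phenyl still keeps an edge, with a number 18 percentage points lower from compound 1 to compound 4 (beyond the scatter). Nothing available here explains the difference between these rings.

As far as these compounds go, whether both fluorines are needed for this response remains open. So does the response with a pyridine ring or a cyclohexyl group in place of the aromatic ring.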